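The source may hold more compounds than are shown below. What is called first, only, known or untested is meant among the compounds shown, and "the series" means these compounds.

Working notes on the series. In a functional assay on MCF7 cells (Homo sapiens) for antiproliferative activity (a higher number here means a weaker inhibitor, a lower number a stronger inhibitor), compound 3 `CC[C@H](C)Cn1c(Cc2cc(OC)c(OC)c(OC)c2)nc2c(N)nc(F)nc21` gives 43700 nM. Its number stands nearest to compound 2 `CCCn1c(Cc2cc(OC)c(OC)c(OC)c2)nc2c(N)nc(F)nc21`, which gives 25100 nM, and furthest from compound 1 `CCCCn1c(Cc2cc(OC)c(OC)c(OC)c2)nc2c(N)nc(F)nc21`, which gives 24000 nM, yet both separations stay within the scatter: a 1.7-fold higher number from compound 2 to compound 3 (0.24 log units; within the scatter) and a 1.8-fold higher number from compound 1 to compound 3 (0.26 log units; within the scatter). The remaining pair is as flat: a 1.0-fold higher number from compound 1 to compound 2 (0.02 log units; within the scatter). The three measured numbers therefore sit together, and no change of the chain on the saturated chain carbon bound to the aromatic nitrogen has yet moved this assay beyond the scatter.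

Compound 4 `C#CCCCn1c(Cc2cc(OC)c(OC)c(OC)c2)nc2c(N)nc(F)nc21` continues that series of changes at the same place: but-3-yn-1-yl in place of sec-butyl on a saturated chain carbon bound to an aromatic nitrogen. The three measured steps bear on it in that each also swaps one saturated chain for another at this carbon, and each was within the scatter. None of them introduces a triple bond, so the data give no direct reading on but-3-yn-1-yl; the expectation can rest only on the flatness seen so far. The step is thus expected to be small in this assay, with no set direction: a 1.4-fold lower number from compound 3 to compound 4 (0.14 log units; within the scatter). Compound 4 is estimated at 32000 nM, with a range from 12000 nM to 85000 nM.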

Compound 4, half-maximal inhibitory concentration: 11000 nM
Compound 4: middle estimate off by 2.9-fold (0.46 log units), on the high side; measured number below the stated range.
By their numbers in this assay, from the lowest: compound 4; then compounds 1, 2 and 3 (each within the scatter of the next).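

In this assay, the saturated chain carbon bound to an aromatic nitrogen now gives its first steps beyond the scatter, with but-3-yn-1-yl in place of sec-butyl producing (a 4.0-fold lower number from compound 3 to compound 4 (0.60 log units; beyond the scatter)). The straight saturated chains give the same reading, with ethynyl in place of hydrogen giving (a 2.3-fold lower number from compound 2 to compound 4 (0.36 log units; beyond the scatter)) and ethynyl in place of methyl giving (a 2.2-fold lower number from compound 1 to compound 4 (0.34 log units; beyond the scatter)), so this position is not indifferent to the chain after all, and compound 4 is the strongest of the four, though all three steps are modest. Nothing at hand explains these steps, and the triple bond can be linked to them only as an observed difference, not as a cause.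

Going by these compounds, whether an alkene, a nitrile or a hydroxyl group in place of the triple bond would give a step of the same size remains open, so the step cannot yet be tied to the triple bond itself. Also open, on these data alone, is whether the same order of compounds would hold in cell lines other than the one in this assay.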